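The source may hold more compounds than are shown below. What is called first, only, known or untested is meant among the compounds shown, and "the series" means these compounds.

Working notes on the series. In a functional assay on NCI-H1975 cells (Homo sapiens) for antiproliferative activity, read by MTT assay, with a stated time of 72 h (on this read-out higher numbers stand for weaker inhibition and lower numbers for stronger inhibition), compound 1 `COc1cc(N(C)CCN(C)C)c(NC(=O)c2ccncc2OC)cc1Nc1nccc(-c2cn(C)c3ccccc23)n1` gives 1010 nM, compound 2 `COc1cc(N(C)CCN(C)C)c(NC(=O)c2cccnc2)cc1Nc1nccc(-c2cn(C)c3ccccc23)n1` gives 1750 nM and compound 3 `COc1cc(N(C)CCN(C)C)c(NC(=O)c2cnccn2)cc1Nc1nccc(-c2cn(C)c3ccccc23)n1` gives 1220 nM. Compound 3 is not separated from either of the others: a 1.2-fold higher number from compound 1 to compound 3 (0.08 log units; within the scatter) and a 1.4-fold lower number from compound 2 to compound 3 (0.16 log units; within the scatter) both stay within the scatter.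

Compound 4 `COc1cc(N(C)CCN(C)C)c(NC(=O)c2ccncn2)cc1Nc1nccc(-c2cn(C)c3ccccc23)n1` is reached from compound 3 by one exchange, pyrimidin-4-yl in place of pyrazin-2-yl on a carbonyl carbon. The two have the same atoms, joined differently.

Going by the values given here, no measured step makes this exact exchange. The closest evidence is the other exchanges on the same carbonyl carbon. Besides the two steps above, there is a 1.7-fold higher number from compound 1 to compound 2 (0.24 log units; within the scatter), also within the scatter. With all three of these steps that small, no change beyond the scatter is expected in this assay.

The expected step is a 1.1-fold higher number from compound 3 to compound 4 (0.03 log units; within the scatter). The estimate for compound 4 is 1300 nM, with an expected range of 650 nM to 2600 nM.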

Compound 4, half-maximal inhibitory concentration: 1560 nM
Beside the measured number, compound 4's estimate is 1.2-fold (0.08 log units) below it; the range from low to high includes it.
By their numbers in this assay, from the lowest: compounds 1, 3, 4 and 2 (each within the scatter of the next).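

In this assay, the exchange of pyrazin-2-yl for pyrimidin-4-yl on a carbonyl carbon, which keeps the same atoms joined differently, gives a 1.3-fold higher number from compound 3 to compound 4 (0.11 log units; within the scatter), and the two other new steps, a 1.1-fold lower number from compound 2 to compound 4 (0.05 log units; within the scatter) and a 1.5-fold higher number from compound 1 to compound 4 (0.19 log units; within the scatter), also stay within the scatter. Going by these compounds alone, the position now holds four different aromatic groups with no step among them beyond the scatter, and this holds for an exchange that leaves the counted hydrogen-bond donors and acceptors unchanged. Nothing measured here offers an explanation for this flat response.

From the compounds shown here alone, whether the response stays flat for a non-aromatic group on this carbonyl carbon, such as a piperidin-4-yl amine or a short chain ending in a carboxylic acid, remains open. Also open, going by these compounds, is whether any group at this position produces a step beyond the scatter.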